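The compounds below may be only part of what the source reports. "The series", "measured", "known", "first", "only" and "open" are said of these compounds alone.

Measured compounds in a toxicity assay on MDCK cells (Canis lupus familiaris) for cytotoxicity, read by crystal violet staining, with a stated time of 48 h; a higher number here means that more compound is tolerated, a lower number that less compound is tolerated:
compound 1, `Cc1ccc2[nH]c(=O)c(CN(Cc3ccccc3)Cc3ccc(C(C)(C)C)cc3)cc2c1`, gives > 5000 nM, a limit of the assay.
compound 2, `CCc1ccc2[nH]c(=O)c(CN(Cc3ccc(C(C)(C)C)cc3)Cc3ccc(F)c(F)c3)cc2c1`, gives > 33000 nM, a limit of the assay.
compound 3, `CCOc1ccc(CN(Cc2ccc(C(C)(C)C)cc2)Cc2cc3cc(C)ccc3[nH]c2=O)cc1`, gives > 10000 nM, a limit of the assay.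

None of these three values is a number; each is a limit at which the cells still tolerated the compound. Compound 2 therefore cannot be ranked against the other two: its limit and theirs simply sit at different test ceilings. Among the compounds with values here, the only step between measured compounds that differ in one place, a step that the two limits leave unreadable from compound 1 to compound 3, ethoxy in place of hydrogen on an aromatic carbon, cannot be read because the limit of > 5000 nM in this assay, at which 1 of the 3 values shown sits, and the limit of > 10000 nM in this assay, at which 1 of the 3 values shown sits, are both limits.

Compound 4, `CCc1ccc2[nH]c(=O)c(CN(Cc3ccc(C(C)(C)C)cc3)C(C)c3ccc(OC(F)F)cc3)cc2c1`, differs from compound 2 by 1-(4-(difluoromethoxy)phenyl)ethyl in place of 3,4-difluorobenzyl on an amine nitrogen. Within the data shown here, no measured step touches the amine nitrogen, so nothing measured gives a size or direction for this change. With every value shown a limit, compound 4 is expected to be tolerated in a similar range, most likely reported again as a limit. For compound 4 the estimate is 30000 nM, within 8000 nM to 100000 nM. The expected step of an at least 1.1-fold lower number from compound 2 to compound 4 (0.04 log units; that floor lies within the scatter) is thus none beyond the scatter.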

Compound 4, half-maximal cytotoxic concentration: > 5000 nM
Compound 4: only a limit was reported; the forecaster's own chance of this, stated with the estimate: 70%; the middle value does not contradict the limit.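

Compound 4 gives > 5000 nM, which is a limit and not a number. Compound 2 also has only a limit, so the step between compound 2 and compound 4 cannot be read. The compounds shown leave open at what concentration any of them harms the cells.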